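The source may hold more compounds than are shown below. What is called first, only, known or untested is meant among the compounds shown, and "the series" means these compounds.

Measured so far in an ADME assay for metabolic stability, read by HPLC, at pH 7.4; a lower number here means that the compound disappears faster, a higher number that the compound lasts longer:
compound 1 `CCCCNC(=O)Oc1ccc(Cl)cc1C(=O)Nc1cccc(Cl)c1`: 43 h
compound 2 `CCCCCNC(=O)Oc1ccc(Cl)cc1C(=O)Nc1cccc(Cl)c1`: 43 h
compound 3 `CCCCCCCCCNC(=O)Oc1ccc(Cl)cc1C(=O)Nc1cccc(Cl)c1`: 43 h

Across the three, no change at the digits printed from compound 1 to compound 2 (within the scatter), no change at the digits printed from compound 1 to compound 3 (within the scatter) and no change at the digits printed from compound 2 to compound 3 (within the scatter); lengthening the chain has not moved the half-life at the digits seen.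

Compound 4 `CCCCCCCCCCNC(=O)Oc1ccc(Cl)cc1C(=O)Nc1cccc(Cl)c1` is not yet measured in this assay. It differs from compound 3 by methyl in place of hydrogen on a saturated chain carbon, nine bonds along the chain from an amide-type nitrogen. The same kind of change was made from compound 1 to compound 2, namely (methyl in place of hydrogen on a saturated chain carbon, four bonds along the chain from an amide-type nitrogen), and there it gave no change at the digits printed from compound 1 to compound 2 (within the scatter). The two cores differ by pentyl in place of hydrogen on a saturated chain carbon, four bonds along the chain from an amide-type nitrogen, so the methyl enters nine bonds along the chain from an amide-type nitrogen rather than four bonds along, which makes it the same kind of change, not the same change.

The step from compound 3 to compound 4 is expected to be no change at the digits printed from compound 3 to compound 4 (within the scatter), resting on compound 1 to compound 2 showing no change at the digits printed from compound 1 to compound 2 (within the scatter) and on compound 3 giving 43 h. Compound 4 is therefore estimated at 43 h, expected between 25 h and 75 h.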

Compound 4, half-life: 43 h
Estimate against measurement, compound 4: no gap at the digits printed, within the range that was stated.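

In this assay the series gives no change at the digits printed from compound 3 to compound 4 (within the scatter), no change at the digits printed from compound 2 to compound 4 (within the scatter) and no change at the digits printed from compound 1 to compound 4 (within the scatter), so what carries from core to core here is only an absence of change, and nothing shows that a step of real size would carry in the same way. Methyl in place of hydrogen holds on two cores: the same change on two cores in this assay, no change at the digits printed (within the scatter) from compound 1 to compound 2 and no change at the digits printed (within the scatter) from compound 3 to compound 4, 1.0-fold (0.00 log units) apart, within the scatter of two such steps Pentyl in place of hydrogen holds on two cores as well: the same change on two cores in this assay, no change at the digits printed (within the scatter) from compound 1 to compound 3 and no change at the digits printed (within the scatter) from compound 2 to compound 4, 1.0-fold (0.00 log units) apart, within the scatter of two such steps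

Every compound shown has an unbranched saturated chain, so the half-life with a branched chain, a longer chain, or a chain carrying an amine or a carboxylic acid stays open. Also open, on these data alone, is whether any change to the shared core would move the half-life.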